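Trifluoromethyl to fluoro in a growth-inhibition series

This account rests on a few compounds, and the source may have more. Where it says the series, first, only, none or still open, it means among the compounds named here.

In a functional assay on NCI/ADR-RES cells (Homo sapiens) for inhibition (a higher number here means a weaker inhibitor of growth, a lower number a stronger inhibitor of growth), compound 1 `O=S(=O)(/C=C/c1ccc(F)cc1F)Cc1ccc(Nc2ncnc3ccccc23)cc1` gives > 100000 nM as a limit of the assay. Going by the values given here, compound 2 `O=S(=O)(/C=C/c1ccc(C(F)(F)F)cc1F)Cc1ccc(Nc2ncnc3ccc(Br)cc23)cc1` reads 85000 nM as the only actual number so far. Compound 3 `O=S(=O)(/C=C/c1ccc(F)cc1F)Cc1ccc(Nc2ncnc3ccc(Br)cc23)cc1` differs from compound 2 by one change: fluoro in place of trifluoromethyl on an aromatic carbon with fluoro in place of trifluoromethyl on an aromatic carbon. Among the compounds with values here, no measured step covers this change, so nothing beyond the scatter is expected in this assay and no direction is favoured. The estimated change is a 1.1-fold higher number from compound 2 to compound 3 (0.02 log units; within the scatter) in this reading. For compound 3 the expected value is 90000 nM with an estimated range of 45000 nM to 180000 nM as the working bounds.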

Compound 3, concentration for 50% growth inhibition: 100000 nM
Estimate against measurement, compound 3: 1.1-fold (0.05 log units) below, within the range that was stated.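

In this assay, going by these compounds alone, fluoro in place of trifluoromethyl, on the aromatic carbon para to a large group, gives a 1.2-fold higher number from compound 2 to compound 3 (0.07 log units; within the scatter), the first readable step at this position, and it does not separate 2-fluoro-4-(trifluoromethyl)phenyl from 2,4-difluorophenyl. The value of compound 1, > 100000 nM, is a limit of the assay. Bromo in place of hydrogen on an aromatic carbon gives a number no higher from compound 1 to compound 3 (the limit leaves the size open) and the size of this step cannot be read. Little room remains for a higher number in this series: the limit of > 100000 nM in this assay, at which 1 of the 3 values shown sits.

Still open, from the compounds shown here alone, is whether an amine or a carboxylic acid at this position would give a number beyond the scatter from compound 2.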